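The compounds below may be only part of what the source reports. "The series", "measured", "known", "first", "only" and "open" are said of these compounds alone.

The compounds here all carry a nitrogen bound to an aromatic ring, and each was tested in a functional assay with Cavia porcellus as the target; a lower number here means a stronger inhibitor, a higher number a weaker inhibitor. Compound 2, `COc1ccccc1[N+](C)(C)Cc1ccccc1`, gives in this assay only a limit of the assay, > 3000 nM, and not a number. Compound 1, `C=CC[N+](C)(C)c1ccccc1OC`, gives in this assay 2890 nM. The two differ in one place: vinyl in place of phenyl on a saturated chain carbon bound to a nitrogen on an aromatic ring. The step of an at least 1.0-fold lower number from compound 2 to compound 1 (0.01 log units; that floor lies within the scatter) rests on (the limit of > 3000 nM in this assay, at which 1 of the 3 values shown sits), so only a floor is known for it, and that floor lies within the usual scatter of repeated measurements.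

Compound 3, `COc1ccc(C(=O)COc2ccc([N+](C)(C)Cc3ccccc3)cc2)cc1OC`, carries a longer side arm on its core and gives in this assay 19400 nM, the higher of the two numbers, with a gap to compound 1 that lies beyond the scatter. How the core of compound 3 differs from the core of compound 2 is not broken down here.

Compound 4, `C=CC[N+](C)(C)c1ccc(OCC(=O)c2ccc(OC)c(OC)c2)cc1`, has not yet been measured in this assay. It differs from compound 3 in one place: vinyl in place of phenyl on a saturated chain carbon bound to a nitrogen on an aromatic ring. This is the same change as from compound 2 to compound 1, at the same place. Resting on the step of an at least 1.0-fold lower number from compound 2 to compound 1 (0.01 log units; that floor lies within the scatter), which showed only a floor within the scatter, compound 4 is expected to move by a 1.3-fold lower number from compound 3 to compound 4 (0.11 log units; within the scatter). Compound 4 is expected to give in this assay about 15000 nM, with a likely range from 6000 nM to 40000 nM.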

Compound 4, half-maximal inhibitory concentration: 500 nM
Beside the measured number, compound 4's estimate is 30-fold (1.48 log units) above it, and the stated range ends above it.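

On the core of compound 3, which carries the longer side arm, benzyl gives way to allyl, which amounts to vinyl in place of phenyl on a saturated chain carbon bound to a nitrogen on an aromatic ring, and this change gives a 39-fold lower number from compound 3 to compound 4 (1.59 log units; beyond the scatter) in this assay; on this core, then, the swap has a large effect that lies well beyond the scatter. Set beside the same swap on the other core, the comparison reads: the same change on two cores in this assay, an at least 1.0-fold lower number (0.01 log units; that floor lies within the scatter) from compound 2 to compound 1 and a 39-fold lower number (1.59 log units; beyond the scatter) from compound 3 to compound 4; the limit leaves it open whether they differ. Compound 2 gives only a limit of the assay, > 3000 nM, so the true size of its step stays unknown, and a similar effect on both cores is neither shown nor ruled out, which means that nothing here establishes whether this change carries over from one core to another with the same size.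

The compounds shown leave open whether the gain on this core depends on the double bond of the allyl group or on the loss of the phenyl ring, a question that a saturated propyl chain in the same place could address. They also leave open how a longer chain on that nitrogen, such as a butyl chain, would compare on either core.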